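Thiophene attachment point in the oxindole-anilide series

The source may hold more compounds than are shown below. What is called first, only, known or untested is meant among the compounds shown, and "the series" means these compounds.

Compound 2 `C=C(Br)C(=O)Nc1ccc2c(c1)/C(=C\c1cccs1)C(=O)N2` gives 2300 nM in a functional assay on MCF7 cells (Homo sapiens) for antiproliferative activity, read by MTT assay, with a stated time of 72 h (on this read-out higher numbers stand for weaker inhibition and lower numbers for stronger inhibition), the second highest of the three numbers measured. Compound 1 `C=C(Br)C(=O)Nc1ccc2c(c1)/C(=C/c1cccs1)C(=O)N2` gives 1700 nM, and compound 3 `C#CC(=O)Nc1ccc2c(c1)/C(=C/c1ccc[nH]1)C(=O)N2` gives 3700 nM. Among the measured compounds shown here, the only single-point step measured is a 1.4-fold higher number from compound 1 to compound 2 (0.13 log units; within the scatter), which rests on (the fact that compounds 1 and 2 differ only in the configuration as drawn). Compound 4 `C=C(Br)C(=O)Nc1ccc2c(c1)/C(=C\c1ccsc1)C(=O)N2` differs from compound 2 by thiophen-3-yl in place of thiophen-2-yl on a double-bonded chain carbon bound to a double-bonded ring carbon. For the measured compounds named here, no measured step moves the thiophene attachment point, so nothing here shows how that change acts; the one measured step stayed within the scatter, and a step of similar size is expected here, with no direction claimed. Compound 4 is therefore estimated at 2300 nM (range 1000 nM to 5500 nM), which means an expected step of no change at the digits printed from compound 2 to compound 4 (within the scatter).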

Compound 4, half-maximal inhibitory concentration: 2100 nM
The estimate for compound 4 lay 1.1-fold (0.04 log units) above the measured number; measured number inside the range.
By their numbers in this assay, from the lowest: compounds 1, 4, 2 and 3 (each within the scatter of the next, the first and the last beyond it).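

Moving the thiophene attachment point gives a 1.1-fold lower number from compound 2 to compound 4 (0.04 log units; within the scatter) in this assay, so thiophen-3-yl and thiophen-2-yl cannot be told apart at this place on this read-out. The earlier compounds shown here offered only a step in configuration; this step changes how the ring itself is attached, and it also stays within the scatter. Nothing at hand bears on the reason for this result. Still open, on these data alone, is whether a group other than thiophene, such as a phenyl ring carrying an amine or a carboxylic acid, would shift the number at this place.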